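The compounds below may be only part of what the source reports. "The series", "measured", "known", "first", "only" and "open" are said of these compounds alone.

Of the compounds shown here, two have so far been measured in a functional assay on PC-12 cells (Rattus norvegicus) for cytotoxicity, read by MTT assay, with stated times of 2 h and 24 h, tested at 5 uM; on this read-out higher numbers stand for a stronger effect at the one concentration tested and lower numbers for a weaker effect. Compound 1, `Oc1cc(C(F)(F)F)ccc1-c1nc(-c2ccccc2O)n(-c2ccc(I)cc2)n1`, gives 94.4%. Compound 2, `Oc1cc(C(F)(F)F)ccc1-c1nc(-c2ccccc2O)n(-c2ccccc2Cl)n1`, gives 90.6%. For the measured compounds named here, the one step between them is a number 3.8 percentage points lower from compound 1 to compound 2 (within the scatter), so although the number of compound 2 is the smaller of the two on paper, the gap to compound 1 is within the scatter and the two cannot be ranked against each other.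

Compound 3, `Oc1cc(C(F)(F)F)ccc1-c1nc(-c2ccccc2O)n(-c2ccccc2C(F)(F)F)n1`, has not yet been measured. It differs from compound 2 in one place: trifluoromethyl in place of chloro on an aromatic carbon. Going by the values given here, no measured step touches this group, so the only guide is the step from 4-iodophenyl to 2-chlorophenyl on the aromatic nitrogen, which exchanged a whole ring and still stayed within the scatter. Both measured values are high and close together, and a change at a single aromatic carbon gives no ground for expecting a shift beyond the scatter. Compound 3 is therefore expected to give about 90% in this assay, within a range of 78% to 98%, which means an expected step of a number 0.6 percentage points lower from compound 2 to compound 3 (within the scatter).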

Compound 3, a percentage reported as activity, at one concentration (the size of the read-out at that concentration, not a potency): 80%
For compound 3 the middle estimate is 10 percentage points above the measured one, within the range that was stated.
By their numbers in this assay, from the lowest: compound 3; then compounds 2 and 1 (each within the scatter of the next).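

In this assay, for the compounds shown here, the group on this aromatic carbon turns out to matter: a number 10.6 percentage points lower from compound 2 to compound 3 (beyond the scatter), the first step that lies beyond the scatter, though it is still modest in size. The change is small on paper, since chloro, with 1 heavy atom, gives way to trifluoromethyl, with 4 heavy atoms, at a place ortho to a large group, and neither group has any hydrogen-bond donors or acceptors. The wider comparison points the same way, a number 14.4 percentage points lower from compound 1 to compound 3 (beyond the scatter), which makes compound 3 the lowest of the three, but no measurement available here accounts for the drop.

With only two groups compared on this carbon, the compounds shown leave open whether the number follows the count of heavy atoms or something else particular to trifluoromethyl, and how a methoxy group or an amine would read at the same place. As each figure comes from a single concentration, they also leave open how the three compounds would compare at other concentrations.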